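Acetyl on the amine of compound 2

This account rests on a few compounds, and the source may have more. Where it says the series, first, only, none or still open, it means among the compounds named here.

In a functional assay on A549 cells (Homo sapiens) for antiproliferative activity, read by MTT assay, with a stated time of 48 h (on this read-out lower numbers stand for stronger inhibition and higher numbers for weaker inhibition), compound 1 `CCN(CC)Cc1ccc2c(c1O)-c1ccc(cc1O)CCc1ccc(O)c(c1)Oc1ccc(cc1)CC2` gives 5740 nM as a true number. Compound 2 `Nc1cc2cc(c1O)Oc1ccc(cc1)CCc1cccc(O)c1-c1ccc(cc1O)CC2` gives only > 20000 nM as a limit and not a number. Compound 3 `CC(=O)Nc1cc2cc(c1O)Oc1ccc(cc1)CCc1cccc(O)c1-c1ccc(cc1O)CC2` differs from compound 2 in one place by acetyl in place of hydrogen on a nitrogen on an aromatic ring with acetyl in place of hydrogen on a nitrogen on an aromatic ring, amino to acetamido. Going by the values given here, no measured pair shows this change. In this assay only a small move toward stronger inhibition is expected, hardly beyond the scatter. The estimated move is an at least 1.2-fold lower number from compound 2 to compound 3 (0.09 log units; that floor lies within the scatter) and it stays uncertain. Compound 3 is estimated at 16000 nM with 6000 nM to 40000 nM as its range.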

Compound 3, half-maximal inhibitory concentration: > 20000 nM
Compound 3 gave a limit, no number; the forecaster's own chance of this, stated with the estimate: 50%; middle value at least 1.2-fold (0.09 log units) away from the limit.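

Compound 2 and compound 3 each give only a limit in this assay, not a number, so no step between them can be read: the limit of > 20000 nM in this assay, at which 2 of the 3 values shown sit.

On these data alone, whether amino to acetamido shifts the read-out in either direction stays open.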